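The source may report more compounds than this note shows. Statements on the series, on what has been measured and on what is new or still open speak of the compounds shown alone.

Compound 2 `CN(C)CCn1cnnc1-c1cc(Oc2ccc(NC(=O)N/N=C/c3ccccc3)cc2F)ccn1` carries a phenyl on the carbon with a double bond to nitrogen. In a functional assay on MKN-45 cells (Homo sapiens) for cytotoxicity, read by MTT assay, with a stated time of 72 h (a lower number here means a stronger inhibitor, a higher number a weaker inhibitor), compound 2 gives 2730 nM, the highest of the three numbers shown: compound 1 `COc1ccc(OC)c(/C=N/NC(=O)Nc2ccc(Oc3ccnc(-c4nncn4CCN(C)C)c3)c(F)c2)c1` gives 1510 nM, and compound 3 `CN(C)CCn1cnnc1-c1cc(Oc2ccc(NC(=O)N/N=C/c3cccc(Br)c3)cc2F)ccn1` gives 450 nM. The step of a 1.8-fold higher number from compound 1 to compound 2 (0.26 log units; within the scatter) is within the scatter, whereas the step of a 6.1-fold lower number from compound 2 to compound 3 (0.78 log units; beyond the scatter) and the step of a 3.4-fold lower number from compound 1 to compound 3 (0.53 log units; beyond the scatter) are both modest and beyond it.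

Compound 4 `COc1ccc(/C=N/NC(=O)Nc2ccc(Oc3ccnc(-c4nncn4CCN(C)C)c3)c(F)c2)cc1O` differs from compound 2 in one place: 3-hydroxy-4-methoxyphenyl in place of phenyl on a carbon with a double bond to nitrogen. The nearest measured precedent is compound 1, whose 2,5-dimethoxyphenyl gave a number within the scatter of compound 2. Among the measured compounds shown here, no measured step shows a hydroxy group on this ring, and the only step beyond the scatter here comes from bromo in compound 3, which is not involved in this change. Compound 4 is therefore expected to stay close to compound 2 in this assay, with a step of a 1.5-fold lower number from compound 2 to compound 4 (0.18 log units; within the scatter) at most. The estimate for compound 4 is 1800 nM, in a range from 600 nM to 5000 nM.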

Compound 4, half-maximal inhibitory concentration: 2510 nM
Compound 4: the middle estimate sits 1.4-fold (0.14 log units) below what was measured, and the stated range covers the measured number.
By their numbers in this assay, from the lowest: compound 3; then compounds 1, 4 and 2 (each within the scatter of the next).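

In this assay, the 3-hydroxy-4-methoxyphenyl of compound 4 brings a hydrogen-bond donor and hydrogen-bond acceptors to this carbon, yet the step of a 1.1-fold lower number from compound 2 to compound 4 (0.04 log units; within the scatter) shows no separation from plain phenyl. The step of a 1.7-fold higher number from compound 1 to compound 4 (0.22 log units; within the scatter) likewise shows no separation from 2,5-dimethoxyphenyl, so two differently oxygenated rings now sit within the scatter of phenyl, while the step of a 5.6-fold higher number from compound 3 to compound 4 (0.75 log units; beyond the scatter) leaves 3-bromophenyl as the only ring here set apart from the others. Nothing available explains these numbers.

The compounds shown leave open whether the advantage of 3-bromophenyl is specific to bromo or is shared by a chloro or trifluoromethyl group on the ring. They also leave open how a ring bearing a carboxylic acid or an amine would behave at this carbon.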